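Methylsulfonyl for methylsulfanyl in an imidazoline series

The source may hold more compounds than are shown below. What is called first, only, known or untested is meant among the compounds shown, and "the series" means these compounds.

Measured so far in a functional assay for agonist activity at Alpha-1A adrenergic receptor (Homo sapiens); a lower number here means a smaller maximal response, a higher number a larger maximal response:
compound 1 `CS(=O)(=O)c1ccc(Cl)cc1NCC1=NCCN1`, 91%
compound 2 `CSc1ccc(Cl)cc1NCC1=NCCN1`, 82%
compound 3 `CSc1ccc(C(F)(F)F)cc1NCC1=NCCN1`, 111%

The change methylsulfonyl in place of methylsulfanyl on an aromatic carbon made a number 9 percentage points higher from compound 2 to compound 1 (within the scatter). The two cores differ by trifluoromethyl in place of chloro on an aromatic carbon, which made a number 29 percentage points higher from compound 2 to compound 3 (beyond the scatter). Compound 4 `CS(=O)(=O)c1ccc(C(F)(F)F)cc1NCC1=NCCN1` is the unmeasured partner of compound 3 and differs from it by methylsulfonyl in place of methylsulfanyl on an aromatic carbon. This is the same kind of change as from compound 2 to compound 1, but around the place the ring carbon is para to a trifluoromethyl group (4 heavy atoms) rather than para to a chloro group (1 heavy atom). Because a number 9 percentage points higher from compound 2 to compound 1 (within the scatter) was within the scatter, the expected step is a number 5 percentage points higher from compound 3 to compound 4 (within the scatter), small and uncertain in sign. Compound 4 is therefore estimated at 116% in this assay, with the expected range 100% to 132%.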

Compound 4, largest response reached (reported as maximum), in percent of the reference or control that the assay uses: 95%
Compound 4: the middle estimate sits 21 percentage points above what was measured; the whole stated range lies above it.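

In this assay, methylsulfonyl in place of methylsulfanyl does not carry over unchanged from one core to the other; para to a trifluoromethyl group it gives a number 16 percentage points lower from compound 3 to compound 4 (beyond the scatter) and differs from the step on the chloro core: the same change on two cores in this assay, a number 9 percentage points higher (within the scatter) from compound 2 to compound 1 and a number 16 percentage points lower (beyond the scatter) from compound 3 to compound 4, 25 percentage points apart, beyond the scatter of two such steps. Read the other way, trifluoromethyl in place of chloro gives only a number 4 percentage points higher from compound 1 to compound 4 (within the scatter) when methylsulfonyl is present, so this change also depends on its partner group: the same change on two cores in this assay, a number 29 percentage points higher (beyond the scatter) from compound 2 to compound 3 and a number 4 percentage points higher (within the scatter) from compound 1 to compound 4, 25 percentage points apart, beyond the scatter of two such steps. The two changes are therefore not additive across these four compounds, but two cores give no reason for the difference and no rule for any further core.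

Still open, from the compounds shown here alone, is whether a methylsulfinyl group would behave like methylsulfanyl or methylsulfonyl. Also open, going by these compounds, is how either sulfur group would respond with a nitrile or a methoxy group in place of chloro or trifluoromethyl.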